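Halogen swap on the benzylamine arm: growth inhibition notes

This account rests on a few compounds, and the source may have more. Where it says the series, first, only, none or still open, it means among the compounds named here.

The three measured compounds share one core, seen in compound 1 `O=S(=O)(NCCNCc1ccc(-c2ccccc2)cc1)c1cc(C(F)(F)F)cc(C(F)(F)F)c1`, compound 2 `O=S(=O)(NCCCNCc1cccc(Cl)c1)c1cc(C(F)(F)F)cc(C(F)(F)F)c1` and compound 3 `O=S(=O)(NCCNCc1cccc2ccccc12)c1cc(C(F)(F)F)cc(C(F)(F)F)c1`. In a toxicity assay on MCF-10A cells (Homo sapiens) for inhibition, read by MTT assay, with a stated time of 72 h (a higher number here means a weaker inhibitor of growth, a lower number a stronger inhibitor of growth), compound 1 gives 3300 nM, compound 2 gives 7000 nM and compound 3 gives 22000 nM. Among these three numbers compound 2 stands second highest; its nearest neighbour is compound 1, a gap beyond the scatter, and its furthest is compound 3, also beyond the scatter. For the measured compounds named here, no two of the measured compounds differ in one place only, so no single-change step is known within the set.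

Compound 4 `O=S(=O)(NCCCNCc1ccc(Br)cc1)c1cc(C(F)(F)F)cc(C(F)(F)F)c1` has not yet been measured in this assay. Its difference from compound 2 is 4-bromophenyl in place of 3-chlorophenyl on a saturated chain carbon bound to an amine nitrogen. One halogen-bearing phenyl group thus replaces another at the same place, and nothing in the measured set isolates such a swap. The step from compound 2 to compound 4 is expected to be small, a 1.2-fold lower number from compound 2 to compound 4 (0.07 log units; within the scatter), in neither direction beyond the scatter. Compound 4 is expected to give 6000 nM in this assay, within a range from 2500 nM to 16000 nM.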

Compound 4, concentration for 50% growth inhibition: 3100 nM
Beside the measured number, compound 4's estimate is 1.9-fold (0.29 log units) above it, within the range that was stated.
By their numbers in this assay, from the lowest: compounds 4 and 1 (each within the scatter of the next); then compound 2; then compound 3.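

At the saturated chain carbon bound to an amine nitrogen, the swap to 4-bromophenyl in place of 3-chlorophenyl is not neutral: in this assay the series shows a 2.3-fold lower number from compound 2 to compound 4 (0.35 log units; beyond the scatter) as a modest step. For the compounds shown here, this is the first single-change step in the set, and it shows that one halogen-bearing phenyl group can shift the number relative to another, though the heavy-atom count of the group stays the same and no hydrogen-bond donors or acceptors enter or leave. No measurement at hand accounts for this step.

The swap changes both the halogen and its place on the ring, so the compounds shown do not separate the two. Still open, going by these compounds, is how 4-chlorophenyl, 3-bromophenyl or unsubstituted phenyl would read at this place.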